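Cyclopentyl in Place of Pentan-3-yl: an Expected Step

This account rests on a few compounds, and the source may have more. Where it says the series, first, only, none or still open, it means among the compounds named here.

Compound 1 `Cc1cc(C(/C=C2\OC(=O)NC2=O)C(C)C)c(=O)[nH]c1-c1ccc2cccc(F)c2c1`: 23 nM
Compound 2 `CCC(CC)C(/C=C1\OC(=O)NC1=O)c1ccc(-c2ccc3cccc(F)c3c2)[nH]c1=O`: 13 nM

Both numbers come from an assay on membranes from Chem-1 cells for displacement of a labelled ligand from prostaglandin E2 receptor EP3 subtype (Homo sapiens), read by scintillation counting, with a stated time of 2 h; a higher number here means a weaker inhibitor, a lower number a stronger inhibitor. Compound 2 holds the lower of the two, yet its gap to compound 1 lies within the usual scatter, so the two cannot be ranked. Compound 3 `O=C1NC(=O)/C(=C/C(c2ccc(-c3ccc4cccc(F)c4c3)[nH]c2=O)C2CCCC2)O1` differs from compound 2 in a single place: cyclopentyl in place of pentan-3-yl on a saturated chain carbon bound to an aromatic carbon and a double-bonded chain carbon. The counted size of what leaves and what enters is the same, and neither carries a donor or an acceptor, so in this assay the expected step is a 1.2-fold higher number from compound 2 to compound 3 (0.06 log units; within the scatter), in neither direction beyond the scatter. Compound 3 is therefore estimated at 15 nM, within a range from 6 nM to 40 nM.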

Compound 3, inhibition constant: 9 nM
Compound 3: the middle estimate sits 1.7-fold (0.22 log units) above what was measured; low and high end bracket the measured number.
By their numbers in this assay, from the lowest: compounds 3, 2 and 1 (each within the scatter of the next, the first and the last beyond it).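

At this saturated chain carbon, cyclopentyl can stand in for pentan-3-yl: in this assay the swap gives a 1.4-fold lower number from compound 2 to compound 3 (0.16 log units; within the scatter), so the two groups cannot be ranked. Joining the ends of the open chain into a ring therefore costs nothing that this measurement can detect. Nothing available explains why the two groups give such similar numbers.

Still open, on these data alone, is how a smaller cyclobutyl ring, a larger cyclohexyl ring or a flat phenyl ring would fare at this carbon. Also open, as far as these compounds go, is whether an amine or a carboxylic acid on the group would be accepted there.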